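The compounds below may be only part of what the source reports. "The series", "measured", "known", "first", "only" and "open" are said of these compounds alone.

Measured so far in a functional assay on SW-620 cells (Homo sapiens) for inhibition; on this read-out lower numbers stand for stronger inhibition and higher numbers for weaker inhibition:
compound 1 `CCN1C(=O)NC2(CSC3=C2C(=O)c2ccccc2C3=O)C1=O` — 203 nM
compound 2 `CCCCN1C(=O)NC2(CSC3=C2C(=O)c2ccccc2C3=O)C1=O` — 740 nM

Compound 1 stands lowest of the two numbers in this assay; compound 2 gives 740 nM. Within the data shown here, the one step measured, a 3.6-fold higher number from compound 1 to compound 2 (0.56 log units; beyond the scatter), grew the chain at the same place. Compound 3 `NCCCN1C(=O)NC2(CSC3=C2C(=O)c2ccccc2C3=O)C1=O` differs from compound 1 by aminomethyl in place of hydrogen on a saturated chain carbon, two bonds along the chain from an amide-type nitrogen in a ring. Among the measured compounds shown here, the chain grows as in the step to compound 2, so a weakening of similar size is expected, tempered by the added donor and acceptor of the aminomethyl, for which no step is known. Compound 3 is thus expected to show a 2.2-fold higher number from compound 1 to compound 3 (0.35 log units; beyond the scatter), giving an estimate of 450 nM with a range from 150 nM to 1400 nM.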

Compound 3, half-maximal inhibitory concentration: 52 nM
Estimate against measurement, compound 3: 8.7-fold (0.94 log units) above; measured number below the stated range.
By their numbers in this assay, from the lowest: compound 3; then compound 1; then compound 2.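

In this assay, chain growth at this position need not cost activity: ethyl to 3-aminopropyl gives a 3.9-fold lower number from compound 1 to compound 3 (0.59 log units; beyond the scatter), whereas the step without the amino group gives a 3.6-fold higher number from compound 1 to compound 2 (0.56 log units; beyond the scatter). Amino in place of methyl, three bonds along the chain from an amide-type nitrogen in a ring, gives a 14-fold lower number from compound 2 to compound 3 (1.15 log units; beyond the scatter), so the outcome here depends on the amino group and not on chain growth alone. No evidence is available on what lies behind this difference.

Open, on these data alone, is whether the amino group works only at this chain length, which a 2-aminoethyl or 4-aminobutyl chain would test. Also open, as far as these compounds go, is whether a dimethylamino group, a hydroxyl or a carboxylic acid in its place would give a similar number.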